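Replacing chloro with phenoxy on compound 2

A few compounds are considered here, and "the series" means these few. Any claim that something is new, unique, unknown or untested is made for them only; others in the source may bear on it.

In a functional assay on HT-29 cells (Homo sapiens) for antiproliferative activity, read by sulforhodamine B assay, with a stated time of 48 h (on this read-out lower numbers stand for stronger inhibition and higher numbers for weaker inhibition), compound 2 `O=C1NCCN1c1ccc(S(=O)(=O)Nc2cccc(Cl)c2)cc1` gives 55 nM and lies within the scatter of compound 1 `CCc1cccc(NS(=O)(=O)c2ccc(N3CCNC3=O)cc2)c1` at 110 nM in this pair. Compound 3 `O=C1NCCN1c1ccc(S(=O)(=O)Nc2cccc(Oc3ccccc3)c2)cc1` differs from compound 2 by phenoxy in place of chloro on an aromatic carbon with phenoxy in place of chloro on an aromatic carbon. Within the data shown here, the only measured step that bears on this is a 2.0-fold lower number from compound 1 to compound 2 (0.30 log units; within the scatter) for chloro in place of ethyl, and that exchange brought in no ring, so it guides the expectation only loosely. The expected change is a modest rise in the number in this assay (a 2.4-fold higher number from compound 2 to compound 3 (0.37 log units; beyond the scatter)). Compound 3 is estimated at 130 nM (range 30 nM to 600 nM).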

Compound 3, half-maximal inhibitory concentration: 200 nM
The estimate for compound 3 lay 1.5-fold (0.19 log units) below the measured number; measured number inside the range.
By their numbers in this assay, from the lowest: compounds 2, 1 and 3 (each within the scatter of the next, the first and the last beyond it).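

Phenoxy is the first group at this aromatic carbon, meta to a large group, that brings in a ring, and in this assay its exchange for chloro gives a 3.6-fold higher number from compound 2 to compound 3 (0.56 log units; beyond the scatter) and costs some of the inhibition seen with chloro. Set against ethyl, the same group gives a 1.8-fold higher number from compound 1 to compound 3 (0.26 log units; within the scatter) and cannot be told apart from it. Nothing measured here accounts for the step.

The compounds shown leave open whether the ring or the oxygen carries the step, which methoxy or an unlinked phenyl would help to separate. Going by these compounds, how an amine or a carboxylic acid would fare at this carbon also stays open.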